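Swapping Bromo for Methoxy on the Phenoxy Ring

The compounds below may be only part of what the source reports. "The series", "measured", "known", "first", "only" and "open" are said of these compounds alone.

Measured compounds in a functional assay on SMMC-7721 cells (Homo sapiens) for inhibition, read by MTT assay, with a stated time of 72 h, tested at 25 uM; a higher number here means more inhibition at the concentration tested (going by the name of the read-out), a lower number less inhibition:
- compound 1, `CCc1nn(C)c(CO/N=C/c2c(C)nn(C)c2Oc2cccc(C)c2)c1Cl`: < 80%, a limit of the assay rather than a number
- compound 2, `Cc1nn(C)c(Oc2ccc(Cl)cc2)c1/C=N\OCc1c(Cl)c(-c2ccc(Cl)cc2)nn1C`: 80%
- compound 3, `Cc1nn(C)c(Oc2ccc(Br)cc2)c1/C=N\OCc1c(Cl)c(-c2ccc(Cl)cc2)nn1C`: 80%

Compound 3 stands level with compound 2 at the digits shown, and the single measured step that connects them, no change at the digits printed from compound 2 to compound 3 (within the scatter), stays within the scatter. Among the compounds with values here, for compound 1 only a limit is known, and the limit of < 80% in this assay, at which 1 of the 3 values shown sits, says that this is where one of the three values sits, so compound 1 offers no measured step to lean on.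

Within the data shown here, the unmeasured compound 4, `COc1ccc(Oc2c(/C=N\OCc3c(Cl)c(-c4ccc(Cl)cc4)nn3C)c(C)nn2C)cc1`, keeps the shared core of compound 3 and changes only one group on the phenoxy ring: methoxy in place of bromo on an aromatic carbon. Among the measured compounds shown here, the one step that bears on this, from compound 2 to compound 3, was a change of halogen and produced no movement beyond the scatter. For the measured compounds named here, the change to methoxy is of a different kind, and no measured step speaks to it directly, so the expectation rests on the flat behaviour seen so far.

Compound 4 is therefore expected to stay close to compound 3, with a step of about a number 5 percentage points lower from compound 3 to compound 4 (within the scatter) and an estimated value of 75%, ranging from 45% to 90%.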

Compound 4, a percentage reported as inhibition, at one concentration (the size of the read-out at that concentration, not a potency): 80%
Compound 4: the middle estimate sits 5 percentage points below what was measured; low and high end bracket the measured number.
By their numbers in this assay, from the lowest: compounds 2, 3 and 4 (each within the scatter of the next).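

In this assay, the earlier step only traded one halogen for another, whereas this one puts a group of a different kind at the same place, para to a large group: no change at the digits printed from compound 3 to compound 4 (within the scatter), and no change at the digits printed from compound 2 to compound 4 (within the scatter). Going from 4-bromophenoxy to 4-methoxyphenoxy replaces one heavy atom with two and adds a hydrogen-bond acceptor, yet the read-out stays where it was, so the flat behaviour at this position now covers chloro, bromo and methoxy. Since this read-out is the size of the effect at one concentration and not a potency, these three compounds can only be called level, and nothing here ranks them.

Within the data shown here, compound 1 carries a limit and not a number, so it adds no measured step: the limit of < 80% in this assay, at which 1 of the 4 values shown sits. Whether this position stays as flat with an amine, a carboxylic acid or a longer chain such as butoxy in place of methoxy remains open, as the three groups shown here are all small and none of them carries a charge.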